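This account rests on a few compounds, and the source may have more. Where it says the series, first, only, none or still open, it means among the compounds named here.

Measured compounds and their values:
compound 1 `O=C1CC(c2cnc(C(F)(F)F)s2)CN1c1cnn2c1CN(C(=O)Nc1cc(F)c(F)c(F)c1)C(C1CC1)C2`: 38500 nM
compound 2 `O=C1CC(C(F)(F)F)CN1c1cnn2c1CN(C(=O)Nc1cc(F)c(F)c(F)c1)C(C1CC1)C2`: 115000 nM
compound 3 `O=C1CC(c2ncc(F)cn2)CN1c1cnn2c1CN(C(=O)Nc1cc(F)c(F)c(F)c1)C(C1CC1)C2`: 115000 nM

In a toxicity assay on HepG2 2.2.15 cells (Homo sapiens) for cytotoxicity, read by CellTiter-Glo (a lower number here means that less compound is tolerated, a higher number that more compound is tolerated), compound 2 gives 115000 nM and stands level with compound 3, the two together at the top of the three numbers; compound 2 and compound 3 differ by no change at the digits printed from compound 2 to compound 3 (within the scatter). Compound 1 sits furthest away, with a 3.0-fold higher number from compound 1 to compound 2 (0.48 log units; beyond the scatter) and, from the other side, a 3.0-fold higher number from compound 1 to compound 3 (0.48 log units; beyond the scatter).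

Compound 4 `O=C(Nc1cc(F)c(F)c(F)c1)N1Cc2c(-c3ccc(F)cc3)cnn2CC1C1CC1` has not yet been measured. It differs from compound 2 in this way: 4-fluorophenyl in place of 2-oxo-4-(trifluoromethyl)pyrrolidin-1-yl on an aromatic carbon. All three measured steps only swap the group on a saturated ring carbon of the pyrrolidinone and leave that ring in place; none removes the ring or puts an aromatic group on the aromatic carbon. Those steps were modest or within the scatter, so the measured compounds give no direct guide for this change. With nothing pointing in either direction, compound 4 is expected to stay near compound 2, and the step of a 1.6-fold lower number from compound 2 to compound 4 (0.22 log units; within the scatter) is estimated to be modest at most. Compound 4 is therefore expected at about 70000 nM, between 25000 nM and 150000 nM in this assay.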

Compound 4, half-maximal cytotoxic concentration: 38500 nM
Compound 4: middle estimate off by 1.8-fold (0.26 log units), on the high side, and the stated range covers the measured number.
By their numbers in this assay, from the lowest: compounds 1 and 4 (each within the scatter of the next); then compounds 2 and 3 (each within the scatter of the next).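

In this assay, exchanging the whole 2-oxo-4-(trifluoromethyl)pyrrolidin-1-yl on the aromatic carbon for 4-fluorophenyl gives a 3.0-fold lower number from compound 2 to compound 4 (0.48 log units; beyond the scatter) in a single change. This is the first step shown that removes the pyrrolidinone ring itself rather than swapping a group on it, and it shows that less compound is tolerated after this modest change. Compound 4 also prints the same number as compound 1, 38500 nM, although the two carry different groups, and nothing shown explains either value.

As far as these compounds go, it remains open whether the fluorine matters, which plain phenyl in place of 4-fluorophenyl would test. An amine such as morpholin-4-yl on the same aromatic carbon could show whether the number stays nearer compound 2 or compound 4.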